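The source may hold more compounds than are shown below. What is called first, only, known or untested is meant among the compounds shown, and "the series" means these compounds.

Working notes on the series. The shared core carries a propenamide chain on a five-membered aromatic ring, which in turn bears a second ring. Compound 1, `C/C(=C\c1cc(C2=CCCC2)co1)C(N)=O`, has a cyclopentenyl ring there and in an ADME assay on NIH3T3 cells (Mus musculus) for cytotoxicity, read by CCK-8 assay, with a stated time of 24 h (a lower number here means a stronger inhibitor, a higher number a weaker inhibitor), compound 1 gives 49300 nM. Compound 2, `C/C(=C\c1ccc(-c2ccc(F)cc2)o1)C(N)=O`, carries a fluorophenyl ring on a furan core and in this assay compound 2 gives 960 nM. Compound 3, `C/C(=C\c1cc(-c2ccc(C)cc2)cs1)C(N)=O`, carries a methylphenyl ring on a thiophene core. In this assay compound 3 gives only a limit, > 50000 nM, and no number. This is the limit described by the limit of > 50000 nM in this assay, at which 1 of the 3 values shown sits, so where compound 3 truly stands is not known beyond it.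

Compound 4, `COc1ccc(-c2csc(/C=C(\C)C(N)=O)c2)cc1`, is not yet measured. It differs from compound 3 by methoxy in place of methyl on an aromatic carbon, para to a large group. Among the measured compounds shown here, no measured pair shows the effect of this exchange. For a change of this size on the outer ring, no step beyond the usual scatter is expected in this assay, and compound 4 is expected to sit at or near the limit again. The step from compound 3 to compound 4 is therefore expected to be small, a step that the limit leaves unreadable from compound 3 to compound 4, and compound 4 is estimated at 60000 nM, with a range from 15000 nM to 200000 nM.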

Compound 4, half-maximal inhibitory concentration: > 50000 nM
Compound 4 gave a limit, no number; the forecaster's own chance of this, stated with the estimate: 60%; the middle value is on the limit's open side.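

In this assay compound 4 gives > 50000 nM, which is a limit and not a number. Compound 3 is also held at a limit, so no step can be read between compound 3 and compound 4: the limit of > 50000 nM in this assay, at which 2 of the 4 values shown sit. The compounds shown leave open whether methoxy in place of methyl on an aromatic carbon changes the value in this assay at all.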